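A (2-nitrophenyl)sulfonyl group on compound 3

This account rests on a few compounds, and the source may have more. Where it says the series, first, only, none or still open, it means among the compounds named here.

In a functional assay on RKOp27 cells (Homo sapiens) for cytotoxicity, read by MTT assay, with a stated time of 3 days (a lower number here means a stronger inhibitor, a higher number a weaker inhibitor), compound 1 (`N#Cc1c(Nc2nccs2)nc(SCc2nc3ccccc3[nH]2)nc1-c1ccccc1`) gives 3.2 nM and compound 2 (`N#Cc1c(NC(N)=O)nc(SCc2nc3ccccc3[nH]2)nc1-c1ccccc1`) gives 2.5 nM while compound 3 (`CN1CCN(c2nc(SCc3nc4ccccc4[nH]3)nc(-c3ccccc3)c2C#N)CC1`) gives 5.4 nM on the same test. Two steps place compound 3 against the others (a 1.7-fold higher number from compound 1 to compound 3 (0.23 log units; within the scatter)) and (a 2.2-fold higher number from compound 2 to compound 3 (0.33 log units; beyond the scatter)). Compound 4 (`N#Cc1c(-c2ccccc2)nc(SCc2nc3ccccc3[nH]2)nc1N1CCN(S(=O)(=O)c2ccccc2[N+](=O)[O-])CC1`) keeps the core of compound 3 but carries (2-nitrophenyl)sulfonyl in place of methyl on an amine nitrogen in a ring. Going by the values given here, no measured pair changes that nitrogen. The two steps into compound 3 exchange the whole group on the aromatic carbon, so they bear on this change only indirectly, yet neither moved the number far. Among the compounds with values here, a small shift toward a higher number is therefore expected, with wide margins because no measured step covers this nitrogen. The estimated change is (a 1.7-fold higher number from compound 3 to compound 4 (0.22 log units; within the scatter)) and it may prove to lie within the scatter. Compound 4 is estimated at 9 nM within an expected range (2.5 nM to 35 nM).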

Compound 4, half-maximal inhibitory concentration: 5.6 nM
Compound 4: the middle estimate sits 1.6-fold (0.21 log units) above what was measured, within the range that was stated.
By their numbers in this assay, from the lowest: compounds 2, 1, 3 and 4 (each within the scatter of the next, the first and the last beyond it).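

Going by these compounds alone, the ring nitrogen that no earlier pair had changed now has a measured step in this assay: a 1.0-fold higher number from compound 3 to compound 4 (0.02 log units; within the scatter). Methyl, with 1 heavy atom, gives way on this amine nitrogen to (2-nitrophenyl)sulfonyl, with 12 heavy atoms and one six-membered aromatic ring of carbon only, yet the step stays within the scatter, so this assay does not separate the two groups at this position. Nothing measured here offers an explanation for this result.

With a single large group on this nitrogen, the compounds shown leave open how a plain phenylsulfonyl, an acetyl group or a hydrogen on the same nitrogen would read. They also leave open whether the nitro group on the benzene ring plays any part in the number for compound 4, or whether a longer chain carrying a carboxylic acid would read the same.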